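A few compounds are considered here, and "the series" means these few. Any claim that something is new, unique, unknown or untested is made for them only; others in the source may bear on it.

Working notes on the series in a functional assay on OVCAR-8 cells (Homo sapiens) for antiproliferative activity; on this read-out lower numbers stand for stronger inhibition and higher numbers for weaker inhibition

- compound 1 `Cn1ncc(Cl)c1-c1cc(C(=O)N[C@@H]2CN[C@H](CCn3cncn3)C[C@H]2c2ccc(Cl)c(Cl)c2)oc1Cl` gives 1560 nM
- compound 2 `Cn1ncc(Cl)c1-c1cc(C(=O)N[C@@H]2CN[C@H](CC(=O)O)C[C@H]2c2ccc(Cl)c(Cl)c2)oc1Cl` gives 5120 nM

Of these two numbers, compound 2 has the higher at 5120 nM, so it is the weaker inhibitor of the pair. The next compound to be read is compound 3 `Cn1ncc(Cl)c1-c1cc(C(=O)N[C@@H]2CN[C@H](CCO)C[C@H]2c2ccc(Cl)c(Cl)c2)oc1Cl`. The change is hydroxymethyl in place of carboxy on a saturated chain carbon bound to a saturated ring carbon, which puts hydroxymethyl in place of carboxy on a saturated chain carbon bound to a saturated ring carbon. Cut one bond further out, it reads carboxymethyl to 2-hydroxyethyl.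

Among the measured compounds shown here, only one measured step bears on this place: a 3.3-fold higher number from compound 1 to compound 2 (0.52 log units; beyond the scatter). That step brings in carboxy in place of (1H-1,2,4-triazol-1-yl)methyl and is modest but beyond the scatter. For the measured compounds named here, compound 1 at 1560 nM is the only measured compound without carboxy, so a modest move to a lower number is expected in this assay. Going by the values given here, no measured compound carries hydroxymethyl here, so this expectation rests on thin evidence. The expected change is a 2.6-fold lower number from compound 2 to compound 3 (0.41 log units; beyond the scatter). For compound 3 the estimated value is 2000 nM, with an expected range of 700 nM to 5500 nM.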

Compound 3, half-maximal inhibitory concentration: 610 nM
Compound 3: the middle estimate sits 3.3-fold (0.52 log units) above what was measured; the measured number lies below the stated range.
By their numbers in this assay, from the lowest: compound 3; then compound 1; then compound 2.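

In this assay, hydroxymethyl in place of carboxy on a saturated chain carbon bound to a saturated ring carbon gives an 8.4-fold lower number from compound 2 to compound 3 (0.92 log units; beyond the scatter), and this places compound 3 lowest of the three, with its steps to both others beyond the scatter. Hydroxy in place of 1H-1,2,4-triazol-1-yl on a saturated chain carbon, two bonds along the chain from a saturated ring carbon, gives a 2.6-fold lower number from compound 1 to compound 3 (0.41 log units; beyond the scatter), so the triazole ring is not needed for the lowest number seen here, although the lack of a ring does not set the order alone: compound 2 also has no ring at this place and stands highest. Nothing measured here accounts for this order of the three groups.

Still open, on these data alone, is whether a primary amine, a methyl ether or a longer chain ending in hydroxy would give a lower or a higher number than 2-hydroxyethyl at this place. Also open, as far as these compounds go, is whether the same order of groups would hold with other changes to the shared core, since all three compounds carry it unchanged.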